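Triazole sulfonyl series: bromo to trifluoromethyl on the N-aryl

This account rests on a few compounds, and the source may have more. Where it says the series, first, only, none or still open, it means among the compounds named here.

Compound 1 `CSc1nc(-c2ccc(S(N)(=O)=O)cc2)n(-c2ccc(Cl)cc2)n1` gives 32300 nM in a functional assay on B16-F10 cells (Mus musculus) for antiproliferative activity, read by MTT assay, with a stated time of 72 h; a lower number here means a stronger inhibitor, a higher number a weaker inhibitor. Compound 2 `CC(=O)Oc1ccc(/C=C/C(=O)OCCSc2nc(-c3ccc(S(N)(=O)=O)cc3)n(-c3ccc(F)cc3)n2)cc1OC(C)=O` gives 11000 nM in this assay. Compound 3 `COc1cc(/C=C/C(=O)OCCSc2nc(-c3ccc(S(C)(=O)=O)cc3)n(-c3ccc(Br)cc3)n2)ccc1OC(C)=O` gives 12400 nM in this assay. Among these three numbers compound 3 stands second highest. Its value and that of compound 2 lie within the usual scatter of each other, so no order between the two can be read. Compound 1 sits at a higher number than compound 3, and that gap goes beyond the scatter.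

Compound 4 `COc1cc(/C=C/C(=O)OCCSc2nc(-c3ccc(S(C)(=O)=O)cc3)n(-c3ccc(C(F)(F)F)cc3)n2)ccc1OC(C)=O` has not yet been measured. It differs from compound 3 in one place: trifluoromethyl in place of bromo on an aromatic carbon. For the measured compounds named here, no pair of measured compounds differs in this one place, so the size of the step cannot be read from the set. The change is confined to a single substituent and the rest of the molecule is kept, so the step expected in this assay is small, in no clear direction, and most likely within the scatter: a 1.0-fold lower number from compound 3 to compound 4 (0.01 log units; within the scatter). On that basis compound 4 is estimated at 12000 nM in this assay, with a range from 5000 nM to 30000 nM.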

Compound 4, half-maximal inhibitory concentration: 10500 nM
Estimate against measurement, compound 4: 1.1-fold (0.06 log units) above; the range from low to high includes it.
By their numbers in this assay, from the lowest: compounds 4, 2 and 3 (each within the scatter of the next); then compound 1.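

In this assay, for the compounds shown here, the change from 4-bromophenyl to 4-(trifluoromethyl)phenyl gives a 1.2-fold lower number from compound 3 to compound 4 (0.07 log units; within the scatter), the first reading in this set of a change at a single place. The earlier compounds shown here differ from one another in more than one place, so they could not isolate this position; this pair shows that exchanging bromo for trifluoromethyl on this aromatic carbon, para to a large group, leaves the number within the scatter even though the entering group has more heavy atoms. No measured property of either compound is available to bear on this result.

The steps linking compound 1 or compound 2 to compound 3 or compound 4 cannot be read, as each of those pairs differs in more than one place, so the separate contributions of the sulfonyl group, the ester side chain and the other substituents remain unresolved. Going by these compounds alone, also open is whether a group of another kind at this position, such as an amine or a carboxylic acid, would move the number beyond the scatter, since bromo and trifluoromethyl are the only pair compared here.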